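The source may hold more compounds than are shown below. What is called first, only, known or untested is meant among the compounds shown, and "the series" means these compounds.

Measured in an ADME assay on MCF7 cells (Homo sapiens) for cytotoxicity, with a stated time of 72 h; on this read-out lower numbers stand for stronger inhibition and higher numbers for weaker inhibition:
- compound 1 `COc1cc(OC)c(OC)cc1CNc1ncnc2c1ncn2C1CCCCO1`: > 100000 nM
- compound 2 `COc1ccc(CNc2ncnc3c2ncn3C2CCCO2)c(OC)c1`: > 100000 nM
- compound 3 `COc1ccc(OC)c(CNc2ncnc3c2ncn3C2CCCO2)c1`: > 50000 nM

All three values are limits of the assay and not numbers. Compound 3 stands at the limit of > 50000 nM in this assay, at which 1 of the 3 values shown sits. Compound 1 and compound 2 stand at the limit of > 100000 nM in this assay, at which 2 of the 3 values shown sit. Among the compounds with values here, no number is therefore available for any compound, and no step between measured compounds gives a size to work from.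

Compound 4 `COc1cc(OC)c(OC)cc1CNc1ncnc2c1ncn2C1CCCO1` has not yet been measured. It carries methoxy in place of hydrogen on an aromatic carbon of compound 3 (methoxy in place of hydrogen on an aromatic carbon). The new methoxy stands ortho to a methoxy group, meta to a methoxy group and para to a large group.

No step beyond the scatter is expected in this assay, and neither direction is favoured. The estimated change is a step that the limit leaves unreadable from compound 3 to compound 4. A report as a limit is the likely outcome, and for compound 4 the estimate is 75000 nM, with an expected range of 35000 nM to 160000 nM.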

Compound 4, half-maximal inhibitory concentration: > 100000 nM
Compound 4 was reported as a limit; the forecaster's own chance of this, stated with the estimate: 85%; at least 1.3-fold (0.12 log units) between middle value and limit.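

In this assay compound 4 gives > 100000 nM, a limit and not a number. Within the data shown here, no step from compound 1, compound 2 or compound 3 to compound 4 can be read: all four values are limits. The compounds shown leave open whether methoxy in place of hydrogen on an aromatic carbon changes this read-out at all.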